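Amino in place of methoxycarbonyl on a shared core

The source may hold more compounds than are shown below. What is called first, only, known or untested is meant among the compounds shown, and "the series" means these compounds.

In a physicochemical assay for acid dissociation, compound 1 (`NS(=O)(=O)c1ccc(S(=O)(=O)CCCO)cc1`) gives 8.98 and compound 2 (`COC(=O)c1cc(S(N)(=O)=O)ccc1S(=O)(=O)CCCO`) gives 8.9. These two numbers lie within the usual scatter of each other, so compound 2 stands level with compound 1. The next structure, compound 3 (`Nc1cc(S(N)(=O)=O)ccc1S(=O)(=O)CCCO`), carries amino in place of methoxycarbonyl on an aromatic carbon, ortho to a (3-hydroxypropyl)sulfonyl group and meta to a sulfamoyl group: amino in place of methoxycarbonyl on an aromatic carbon. Going by the values given here, one measured step bears on this, with methoxycarbonyl in place of hydrogen on an aromatic carbon: a number 0.08 log units lower from compound 1 to compound 2 (within the scatter). Among the compounds with values here, no measured step involves amino, so that small step is the only guide available. In this assay, the expected result is a modest move toward a higher number, possibly within the scatter: a number 0.20 log units higher from compound 2 to compound 3 (within the scatter). Compound 3 is estimated at 9.1, with an expected range from 8.75 to 9.45.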

Compound 3, acid dissociation constant: 9.15
Estimate against measurement, compound 3: 0.05 log units below; the range from low to high includes it.
By their numbers in this assay, from the lowest: compounds 2, 1 and 3 (each within the scatter of the next).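

Amino now joins hydrogen and methoxycarbonyl at this aromatic carbon, ortho to a (3-hydroxypropyl)sulfonyl group and meta to a sulfamoyl group, and in this assay the change from methoxycarbonyl gives a number 0.25 log units higher from compound 2 to compound 3 (within the scatter) while the change from hydrogen gives a number 0.17 log units higher from compound 1 to compound 3 (within the scatter) on the shared core. Where the earlier compounds showed one substituent at this position, three now stand level, including a swap of methoxycarbonyl, with 0 hydrogen-bond donors, for amino, with 1 hydrogen-bond donor. No measurement is at hand that would explain these numbers.

As far as these compounds go, whether a carboxylic acid or a dimethylamino group at this carbon would also stay within the scatter remains open. So does the effect of a longer chain in place of the 3-hydroxypropyl chain on the sulfonyl group.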